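Replacing a Ring Hydrogen with a Diethylcarbamoyl Group

The source may report more compounds than this note shows. Statements on the series, on what has been measured and on what is new or still open speak of the compounds shown alone.

Compound 1 `c1ccc2c(-c3cnc4[nH]nc(-c5nc6ccccc6[nH]5)c4c3)cncc2c1`: "not determined" (no result reported)
Compound 2 `COCc1cccc2[nH]c(-c3n[nH]c4ncc(-c5ccncc5)cc34)nc12`: > 100000 nM
Compound 3 `CC(C)OCc1cccc2[nH]c(-c3n[nH]c4ncc(-c5cncc6ccccc56)cc34)nc12`: > 100000 nM

All three compounds were examined in an assay on isolated protein for inhibition of proto-oncogene tyrosine-protein kinase receptor Ret (Homo sapiens); a higher number here means a weaker inhibitor, a lower number a stronger inhibitor. For compound 1 the outcome is "not determined" (no result reported), so no number places it on the scale. Compound 2 reached only a limit of the assay, > 100000 nM. Compound 3 likewise gave only a limit, > 100000 nM. The picture is therefore (the limit of > 100000 nM in this assay, at which 2 of the 3 values shown sit). For the measured compounds named here, no two measured compounds differ at a single position, so no measured step size is available from this set.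

Compound 4 `CCN(CC)C(=O)c1cccc2[nH]c(-c3n[nH]c4ncc(-c5cncc6ccccc56)cc34)nc12` differs from compound 1 by diethylcarbamoyl in place of hydrogen on an aromatic carbon. With no measured anchor for compound 1, the direction and size of the change in this assay cannot be read from the data; the expectation rests on (the limit of > 100000 nM in this assay, at which 2 of the 3 values shown sit), which both compound 2 and compound 3 share. Compound 4 is estimated at 50000 nM, within a range from 5000 nM to 200000 nM, with a considerable chance that the assay again reports only a limit.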

Compound 4, half-maximal inhibitory concentration: 1230 nM
Estimate against measurement, compound 4: 41-fold (1.61 log units) above; measured number outside the range, below it.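

For the compounds shown here, with diethylcarbamoyl on this aromatic carbon, compound 4 is the only one of the four compounds to return a measured number in this assay rather than a limit or no result. Compound 3 has isopropoxymethyl at that carbon, and its > 100000 nM is a limit of the assay, not a number. Exchanging isopropoxymethyl for diethylcarbamoyl therefore gives an at least 81-fold lower number from compound 3 to compound 4 (1.91 log units; beyond the scatter), which shows that the group on this carbon can move the reading by a large amount, with the true size left unfixed by the limit at one end.

With no result for compound 1, the change from hydrogen to diethylcarbamoyl cannot be read. The compounds shown also leave open how a dimethylcarbamoyl group, a carboxylic acid or an amine on this carbon would read.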